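Bigger aromatic groups on the sulfonyl: from methylphenyl to biphenyl

The source may report more compounds than this note shows. Statements on the series, on what has been measured and on what is new or still open speak of the compounds shown alone.

Of the compounds shown here, three sharing one core have been tested in a functional assay on PC-3 cells (Homo sapiens) for inhibition; a higher number here means a weaker inhibitor, a lower number a stronger inhibitor. Compound 1 `COc1cc2nc(N3CCN(S(=O)(=O)c4ccc(Cl)s4)CC3)nc(N)c2cc1OC` gives 25000 nM. Compound 2 `COc1cc2nc(N3CCN(S(=O)(=O)c4ccc(C)cc4)CC3)nc(N)c2cc1OC` gives 30000 nM. Compound 3 `COc1cc2nc(N3CCN(S(=O)(=O)c4ccc5ccccc5c4)CC3)nc(N)c2cc1OC` gives 15000 nM. Compound 2 has the highest number of the three, yet its distances to the others are small: a 1.2-fold higher number from compound 1 to compound 2 (0.08 log units; within the scatter), and a 2.0-fold lower number from compound 2 to compound 3 (0.30 log units; within the scatter). Likewise a 1.7-fold lower number from compound 1 to compound 3 (0.22 log units; within the scatter). All three therefore sit within the usual scatter of one another, and none can be called stronger or weaker than the rest.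

Compound 4 `COc1cc2nc(N3CCN(S(=O)(=O)c4ccc(-c5ccc(C(F)(F)F)cc5)cc4)CC3)nc(N)c2cc1OC` is not yet measured. Compared with compound 2 it differs in one place: 4-(trifluoromethyl)phenyl in place of methyl on an aromatic carbon. The closest guide is the step in which a larger aromatic group also replaced 4-methylphenyl on the sulfonyl sulfur, namely a 2.0-fold lower number from compound 2 to compound 3 (0.30 log units; within the scatter), a change that stayed within the scatter. The step of a 1.7-fold lower number from compound 1 to compound 3 (0.22 log units; within the scatter) points the same way and is also within the scatter. On this basis only a small lowering of the number, if any, is expected for compound 4, so the estimated step is a 2.0-fold lower number from compound 2 to compound 4 (0.30 log units; within the scatter). Compound 4 is therefore expected to give about 15000 nM in this assay, within a range from 5000 nM to 45000 nM.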

Compound 4, half-maximal inhibitory concentration: 3300 nM
For compound 4 the middle estimate is 4.5-fold (0.66 log units) above the measured one; the measured number lies below the stated range.
By their numbers in this assay, from the lowest: compound 4; then compounds 3, 1 and 2 (each within the scatter of the next).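

In this assay, for the compounds shown here, replacing methyl with 4-(trifluoromethyl)phenyl gives a 9.1-fold lower number from compound 2 to compound 4 (0.96 log units; beyond the scatter), and this is the first step in the set that lies beyond the scatter. Earlier swaps of one aromatic group for another on the sulfonyl sulfur, such as a 2.0-fold lower number from compound 2 to compound 3 (0.30 log units; within the scatter), stayed within the scatter and separated none of the compounds. This step shows that a change on an aromatic carbon, para to a large group, can move the number clearly when a second six-membered aromatic ring of carbon only enters there. Nothing available here explains why the number falls.

The compounds shown cannot separate the part played by the added ring from that of the trifluoromethyl group it carries; a plain phenyl at the same place would be the direct comparison. From the compounds shown here alone, it also remains open whether other groups there, such as a methoxy group, a carboxylic acid, an amine or a longer alkyl chain, would give a similar step, or whether the added ring is needed at all.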